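This account rests on a few compounds, and the source may have more. Where it says the series, first, only, none or still open, it means among the compounds named here.

Working notes on the hydrazone series built on the shared core of compound 1 `Nc1nc(N/N=C/c2cncs2)nc2c1ncn2[C@@H]1O[C@H](CO)[C@@H](O)[C@H]1O`. In an assay on CHO-K1 cells for displacement of a labelled ligand from adenosine receptor A1 (Homo sapiens), read by scintillation counting, with a stated time of 60 min (on this read-out lower numbers stand for stronger inhibition and higher numbers for weaker inhibition), compound 1 gives 22 nM. Compound 2 `COc1ccc(/C=N/Nc2nc(N)c3ncn([C@@H]4O[C@H](CO)[C@@H](O)[C@H]4O)c3n2)cn1` gives 2.6 nM in this assay, and the step of an 8.5-fold lower number from compound 1 to compound 2 (0.93 log units; beyond the scatter) is modest. Compound 3 `Nc1nc(N/N=C/c2ccc(-n3ccnc3)cc2)nc2c1ncn2[C@@H]1O[C@H](CO)[C@@H](O)[C@H]1O` gives > 10000 nM in this assay, which is a limit of the assay and not a number. That value is the limit of > 10000 nM in this assay, at which 1 of the 3 values shown sits. Compound 3 therefore stands at the weak end of the three shown, with an at least 450-fold higher number from compound 1 to compound 3 (2.65 log units; beyond the scatter) and an at least 3800-fold higher number from compound 2 to compound 3 (3.58 log units; beyond the scatter), both large.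

Compound 4 `CC(=O)Nc1ccc(/C=N/Nc2nc(N)c3ncn([C@@H]4O[C@H](CO)[C@@H](O)[C@H]4O)c3n2)cc1` is not yet measured. It differs from compound 3 by acetamido in place of 1H-imidazol-1-yl on an aromatic carbon. For the measured compounds named here, the steps that bear on this change are the two into compound 3, both large and both losses, which show that the group on the carbon with a double bond to nitrogen can move the number across a wide span; compound 4 keeps the phenyl ring of compound 3 but carries acetamido in place of 1H-imidazol-1-yl. A partial recovery is expected rather than a full return to the level of compound 2, with the step estimated as an at least 66-fold lower number from compound 3 to compound 4 (1.82 log units; beyond the scatter). Compound 4 is estimated at 150 nM in this assay, within a range of 8 nM to 5000 nM, and a result that is again only a limit cannot be ruled out.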

Compound 4, inhibition constant: > 10000 nM
Compound 4 ended at the assay's limit (the forecaster's own chance of this, stated with the estimate: 25%); middle value at least 66-fold (1.82 log units) away from the limit.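

Compound 4 also sits at a limit of the assay and not at a number, as compound 3 does, so the loss does not belong to 1H-imidazol-1-yl alone: the limit of > 10000 nM in this assay, at which 2 of the 4 values shown sit. The change to acetamido leaves the loss large, with an at least 3800-fold higher number from compound 2 to compound 4 (3.58 log units; beyond the scatter) and an at least 450-fold higher number from compound 1 to compound 4 (2.65 log units; beyond the scatter), and both groups on the phenyl ring now end at the weak end of the series. The step between compound 3 and compound 4 cannot be read, as both are limits, so the two groups cannot be ranked against each other.

Still open, on these data alone, is whether the loss goes with the phenyl ring itself or with the group it carries. A phenyl ring bearing only hydrogen, or a methoxy group or an amine in place of acetamido, would bear on that question.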